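The source may report more compounds than this note shows. Statements on the series, on what has been measured and on what is new or still open speak of the compounds shown alone.

Measured so far:
compound 1, `CC(C)c1onc(-c2c(Cl)cccc2Cl)c1COc1ccc(-c2nc3ccc(C(=O)O)cc3n2C)cc1`, 7150 nM
compound 2, `CCC(CC)n1c(-c2ccc(OCc3c(-c4c(Cl)cccc4Cl)noc3C(C)C)cc2F)nc2ccc(C(=O)O)cc21`, > 10000 nM

In an assay on HEK-293T cells for antagonist activity at vitamin D3 receptor (Homo sapiens), read by a luciferase reporter, with a stated time of 24 h (on this read-out lower numbers stand for stronger inhibition and higher numbers for weaker inhibition), compound 1 gives 7150 nM. Compound 2 reaches only the limit of this assay, reported as > 10000 nM, so no number is known for it; (the limit of > 10000 nM in this assay, at which 1 of the 2 values shown sits). The unmeasured compound 3, `CCC(CC)n1c(-c2ccc(OCc3c(-c4c(Cl)cccc4Cl)noc3C(C)C)cc2)nc2ccc(C(=O)O)cc21`, differs from compound 2 by hydrogen in place of fluoro on an aromatic carbon. Among the measured compounds shown here, no pair of measured compounds differs in one place, so no measured step can show how large this change is. With compound 2 at the limit, nothing beyond the usual scatter is expected in either direction. Compound 3 is therefore estimated at 10000 nM, within 4000 nM to 30000 nM. The expected step is a number no higher from compound 2 to compound 3 (the limit leaves the size open).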

Compound 3, half-maximal inhibitory concentration: 5690 nM
Compound 3: the middle estimate sits 1.8-fold (0.24 log units) above what was measured; the range from low to high includes it.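

Hydrogen in place of fluoro on an aromatic carbon gives an at least 1.7-fold lower number from compound 2 to compound 3 (0.24 log units; that floor lies within the scatter) in this assay. Going by these compounds, compound 2 carries only a limit, so this step is a floor and its true size stays open: the limit of > 10000 nM in this assay, at which 1 of the 3 values shown sits. Pentan-3-yl in place of methyl on an aromatic nitrogen gives a 1.3-fold lower number from compound 1 to compound 3 (0.10 log units; within the scatter), so these two groups cannot be told apart in this assay.

The compounds shown leave open how a methoxy group or a nitrile would read in place of this fluoro. They also leave open how an ethyl group would read on the aromatic nitrogen.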